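The source may hold more compounds than are shown below. What is called first, only, known or untested is meant among the compounds shown, and "the series" means these compounds.

Measured so far: compound 1 `COC(=O)/C=C/c1cccc(N(Cc2ccc(/C=C/c3c(Cl)cccc3Cl)cc2)C(=O)C(C)C)c1` with 195 nM; compound 2 `COC(=O)/C=C/c1cccc(N(Cc2ccc(/C=C/c3cc(C(F)(F)F)cc(C(F)(F)F)c3)cc2)C(=O)C(C)C)c1` with 1950 nM.

In an assay on isolated protein with Bile acid receptor (Homo sapiens) as the target (a higher number here means that more compound is needed for the effect, a lower number that less compound is needed), compound 2 stands highest of the two numbers; compound 1 gives the lower value, a gap beyond the usual scatter. Compound 3 `COC(=O)/C=C/c1cccc(N(Cc2ccc(/C=C/c3cccc(C(F)(F)F)c3)cc2)C(=O)C(C)C)c1` differs from compound 2 in one place: hydrogen in place of trifluoromethyl on an aromatic carbon. For the measured compounds named here, no measured pair shows this exact step, so its size is uncertain. A modest downward step is expected, a 2.4-fold lower number from compound 2 to compound 3 (0.39 log units; beyond the scatter), partly because compound 1 already gives 195 nM with a different substituent pattern. Compound 3 is therefore expected near 800 nM, within 300 nM to 2500 nM.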

Compound 3, half-maximal effective concentration: 267 nM
Beside the measured number, compound 3's estimate is 3.0-fold (0.48 log units) above it; measured number below the stated range.
By their numbers in this assay, from the lowest: compounds 1 and 3 (each within the scatter of the next); then compound 2.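

In this assay, hydrogen in place of one trifluoromethyl group gives a 7.3-fold lower number from compound 2 to compound 3 (0.86 log units; beyond the scatter), so the second trifluoromethyl group at this aromatic position comes with a much higher number. For the compounds shown here, the single remaining trifluoromethyl group gives a result matching the 2,6-dichlorophenyl ring, with a 1.4-fold higher number from compound 1 to compound 3 (0.14 log units; within the scatter).

On these data alone, whether a methoxy group or a fluorine atom at this position would keep the number equally low remains open, as does the effect of removing the remaining trifluoromethyl group. Nothing available explains why this step is so large.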